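This account rests on a few compounds, and the source may have more. Where it says the series, first, only, none or still open, it means among the compounds named here.

Two compounds have been examined in a functional assay on UoC-B1 cells (Homo sapiens) for antiproliferative activity, with a stated time of 72 h; on this read-out higher numbers stand for an effect only at larger amounts of compound and lower numbers for an effect already at smaller amounts. Compound 1 `COc1ccc(-c2[nH]c3cc(OC)cc(OC)c3c(=O)c2I)cc1` carries no result there, its entry standing as "not determined" (no result reported). Compound 2 `COC(=O)c1cc(=O)c2cc(NC(=O)Nc3ccc(C(F)(F)F)cc3[N+](=O)[O-])ccc2[nH]1` reaches only a limit of this assay, and that limit for compound 2 reads > 25900 nM. On the numbers shown, compound 2 therefore stands at the limit and not at a number, the one such entry among the two, as the limit of > 25900 nM in this assay, at which 1 of the 2 values shown sits, records. Compound 3 `COC(=O)c1cc(=O)c2cc(NC(=O)Nc3ccc(C(F)(F)F)cc3)ccc2[nH]1` differs from compound 2 by hydrogen in place of nitro on an aromatic carbon. For the measured compounds named here, no step between measured compounds is available to gauge such a change, so the size of the step in this assay is open; with compound 2 resting at the limit (the limit of > 25900 nM in this assay, at which 1 of the 2 values shown sits), no movement beyond the usual scatter is expected in either direction. Compound 3 is thus estimated at 30000 nM, in a range from 8000 nM to 100000 nM. The step this estimate implies, a step that the limit leaves unreadable from compound 2 to compound 3, is expected to be small, and most likely compound 3 will again be reported only as a limit.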

Compound 3, half-maximal effective concentration: > 6350 nM
Compound 3 gave a limit, no number; the forecaster's own chance of this, stated with the estimate: 75%; the middle value does not contradict the limit.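

In this assay, compound 2 and compound 3 are both recorded as limits and not as numbers, and no step can be read between them. The compounds shown leave open what size of change on this read-out hydrogen in place of nitro on an aromatic carbon brings.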